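The source may hold more compounds than are shown below. What is called first, only, known or untested is meant among the compounds shown, and "the series" means these compounds.

Measured so far:
Compound 1, `CCSc1nc2c(cc(-c3ccc(C)cc3)n2-c2ccccc2)c(=N)s1` — in a functional assay on the whole organism for inhibition, with Rattus norvegicus as the target, read by ELISA, with stated times of 30 min and 6 h, at a dose of 30 mg/kg by the oral route (a lower number here means less inhibition, a higher number more inhibition at the dose given (going by the name of the read-out)), compound 1 gives 0%.
Compound 2, `CCSc1nc2c(cc(-c3ccc(Br)cc3)n2-c2ccccc2)c(=N)s1` — in this assay compound 2 gives 1%.
Compound 3, `CCn1c(=S)[nH]c2c(cc(-c3ccc(C)cc3)n2-c2ccccc2)c1=N` — in this assay compound 3 gives 60%.

Compounds 1 and 2 share one core and differ in a single place: bromo in place of methyl on an aromatic carbon. The step of a number 1 percentage points higher from compound 1 to compound 2 (within the scatter) is within the scatter, so the two numbers are read as the same. Compound 3 sits on a different core; how that core differs from the core of compound 1 is not broken down here. Its number in this assay stands beyond the scatter above both compound 1 and compound 2, and it is the highest of the three.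

Compound 4, `CCn1c(=S)[nH]c2c(cc(-c3ccc(Br)cc3)n2-c2ccccc2)c1=N`, has not been measured. It stands to compound 3 as compound 2 stands to compound 1: bromo in place of methyl on an aromatic carbon. The surroundings of the change are described in the same words for both pairs, so this is the same change, made once on each core.

For the measured compounds named here, the only prior reading of this change is the pair of compound 1 and compound 2, where it moved the number by a number 1 percentage points higher from compound 1 to compound 2 (within the scatter). Transferring that onto compound 3, the expected step is no change at the digits printed from compound 3 to compound 4 (within the scatter). Compound 4 is therefore expected to land at about 60% in this assay, estimated between 42% and 76%. This rests on a single pair, measured on a core whose numbers are near zero, so the transfer to the higher-reading core of compound 3 is uncertain.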

Compound 4, a percentage reported as inhibition, in the whole organism at one dose (the size of the read-out at that dose, not a potency): 80%
Estimate against measurement, compound 4: 20 percentage points below; measured number above the stated range.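

In this assay, the change from 4-methylphenyl to 4-bromophenyl gives a number 20 percentage points higher from compound 3 to compound 4 (beyond the scatter), so it does not carry over at one size from one core to the other: the same change on two cores in this assay, a number 1 percentage points higher (within the scatter) from compound 1 to compound 2 and a number 20 percentage points higher (beyond the scatter) from compound 3 to compound 4, 19 percentage points apart, beyond the scatter of two such steps

On the core of compound 3, the bromo group reads higher than the methyl group, whereas on the core of compound 1 the two cannot be told apart, and both numbers there lie close to zero. This does not show why the step depends on the core, whether numbers so close to zero could conceal a step on the core of compound 1, or what size the step would take on a third core, since the comparison rests on just two pairs at one oral dose.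

The compounds shown leave open how other groups would read in the place occupied by methyl and bromo, such as chloro, an amine or a carboxylic acid, and whether any of them would also depend on the core. Also open, going by these compounds, is whether a longer chain, such as propyl, in place of the ethyl group would alter the number on either core or the size of the step between methyl and bromo.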